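A few compounds are considered here, and "the series" means these few. Any claim that something is new, unique, unknown or untested is made for them only; others in the source may bear on it.

Compound 1 `COc1ccc(-c2cnco2)cc1NCc1ccc(C)s1`: 52900 nM
Compound 2 `COc1cc(NCc2ccc(C)s2)ccc1-c1cnco1`: 34400 nM
Compound 3 `COc1cc(/N=C/c2cccs2)ccc1-c1cnco1`: > 100000 nM, a limit

These values come from an ADME assay on Huh-7 cells (Homo sapiens) for cytotoxicity, read by MTT assay, with a stated time of 96 h; on this read-out lower numbers stand for higher toxicity in this test and higher numbers for lower toxicity in this test. Compound 1 and compound 2 give values within the usual scatter of each other. Compound 3 stands at the limit of > 100000 nM in this assay, at which 1 of the 3 values shown sits, so its reading is a limit and not a number.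

Compound 4 `COc1cc(/N=C/c2ccc(F)cc2)ccc1-c1cnco1` differs from compound 3 by a single change, 4-fluorophenyl in place of thiophen-2-yl on a carbon with a double bond to nitrogen. Going by the values given here, no measured pair shows what a single change does in this assay, so any size given here is only an expectation. That expectation leans on compound 2, which gives 34400 nM, and on compound 1, which gives 52900 nM. A modest step toward lower numbers is expected: an at least 1.3-fold lower number from compound 3 to compound 4 (0.12 log units; that floor lies within the scatter). Compound 4 is estimated at 75000 nM, with an expected range from 30000 nM to 100000 nM.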

Compound 4, half-maximal cytotoxic concentration: > 100000 nM
Compound 4: a limit, no number (the forecaster's own chance of this, stated with the estimate: 40%); middle value at least 1.3-fold (0.12 log units) away from the limit.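

In this assay compound 4 gives > 100000 nM as a limit and not a number. Going by these compounds alone, compound 3 reads at the same limit, so no step between compound 3 and compound 4 can be read. Going by these compounds, what 4-fluorophenyl in place of thiophen-2-yl does to the number stays open.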